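The source may hold more compounds than are shown below. What is called first, only, known or untested is meant among the compounds shown, and "the series" means these compounds.

Measured in a functional assay on HT-29 cells (Homo sapiens) for antiproliferative activity, read by sulforhodamine B assay, with a stated time of 72 h; on this read-out lower numbers stand for stronger inhibition and higher numbers for weaker inhibition:
Compound 1 `COc1ccccc1NC(=S)N/N=C/c1ccc2ccccc2n1`: > 100000 nM, a limit.
Compound 2 `CN(C)C(=S)N/N=C/c1cc2cccnc2s1`: 13400 nM.
Compound 3 `NC(=S)N/N=C/c1ccc2cccnc2n1`: 12800 nM.

Compound 1 has no number in this assay, only the limit > 100000 nM. Its true position is therefore open on one side, and any step away from it can only be approximate.

Compound 4 `S=C(N/N=C/c1ccc2ccccc2n1)Nc1cccc(Br)c1` keeps the core of compound 1 and carries 3-bromophenyl in place of 2-methoxyphenyl on an amide-type nitrogen. For the measured compounds named here, no measured pair shows this change, so the expectation rests on little. In this assay a step towards stronger inhibition is expected, of moderate size and beyond the usual scatter. The support for this is weak. On a different core, compound 3 gives a real number at 12800 nM, and compound 2 does the same at 13400 nM. The estimated step is an at least 5.0-fold lower number from compound 1 to compound 4 (0.69 log units; beyond the scatter). Compound 4 is expected at about 20000 nM, with an estimated range from 3000 nM to 100000 nM.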

Compound 4, half-maximal inhibitory concentration: 58900 nM
For compound 4 the middle estimate is 2.9-fold (0.47 log units) below the measured one, within the range that was stated.
By their numbers in this assay, from the lowest: compounds 3 and 2 (each within the scatter of the next); then compound 4. At a limit, above all of these: compound 1.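

For the compounds shown here, with compound 4, the core of compound 1 gains a real number for the first time in this assay: compound 4 gives 58900 nM. With 3-bromophenyl in place of 2-methoxyphenyl on an amide-type nitrogen, the change reads as an at least 1.6-fold lower number from compound 1 to compound 4 (0.22 log units; that floor lies within the scatter), so a lower number is shown, but its size is not pinned down beyond that floor. The step stays a floor because one of its ends is a limit and not a number: the limit of > 100000 nM in this assay, at which 1 of the 4 values shown sits.

Which part of the exchange carries the step remains open: a plain phenyl on that nitrogen would separate the loss of the methoxy group from the gain of the bromine. Also open, as far as these compounds go, is how this core would respond to a phenyl bearing a carboxylic acid or a primary amine.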